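Shortening the Chain on the Ring Nitrogen: Compound 4

The compounds below may be only part of what the source reports. "The series", "measured", "known", "first", "only" and "open" are said of these compounds alone.

Compound 1 `CCCCCN(Cc1ccc(C(=O)NO)cc1)c1ncc(-c2ccc(C)cc2)s1`: 7020 nM
Compound 2 `CCCCCCN(Cc1ccc(C(=O)NO)cc1)c1ncc(-c2ccc(C)cc2)s1`: 7420 nM
Compound 3 `Cc1ccc(-c2cnc(N(Cc3ccc(C(=O)NO)cc3)C(C)C)s2)cc1`: 2180 nM

Three compounds share one core and differ only in the group carried by the nitrogen on the aromatic ring. In a functional assay on HepG2 cells (Homo sapiens) for antiproliferative activity, read by MTT assay, with a stated time of 48 h (on this read-out lower numbers stand for stronger inhibition of growth and higher numbers for weaker inhibition of growth), compound 1 gives 7020 nM, the second highest of the three numbers. Its nearest neighbour is compound 2, with a 1.1-fold higher number from compound 1 to compound 2 (0.02 log units; within the scatter), a change that tells nothing. The furthest is compound 3, with a 3.2-fold lower number from compound 1 to compound 3 (0.51 log units; beyond the scatter); the parallel step a 3.4-fold lower number from compound 2 to compound 3 (0.53 log units; beyond the scatter) points the same way.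

Compound 4 `CCCN(Cc1ccc(C(=O)NO)cc1)c1ncc(-c2ccc(C)cc2)s1` has not yet been measured. It differs from compound 1 by hydrogen in place of ethyl on a saturated chain carbon, three bonds along the chain from a nitrogen on an aromatic ring, so the pentyl group becomes propyl. Going by the values given here, the steps that bear on this are the two that replace a long chain by isopropyl, both modest and both toward lower numbers; the step from pentyl to hexyl, in contrast, lay within the scatter. Propyl sits between pentyl and isopropyl in size, so a smaller move in the same direction is expected, possibly one that does not clear the scatter.

The expected step is a 1.8-fold lower number from compound 1 to compound 4 (0.24 log units; within the scatter). Compound 4 is therefore estimated at 4000 nM, within a range from 2000 nM to 8000 nM.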

Compound 4, concentration for 50% growth inhibition: 2550 nM
Compound 4: the middle estimate sits 1.6-fold (0.20 log units) above what was measured, and the stated range covers the measured number.
By their numbers in this assay, from the lowest: compounds 3 and 4 (each within the scatter of the next); then compounds 1 and 2 (each within the scatter of the next).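

In this assay, going by these compounds alone, shortening pentyl to propyl brings a 2.8-fold lower number from compound 1 to compound 4 (0.44 log units; beyond the scatter) and shortening hexyl to propyl brings a 2.9-fold lower number from compound 2 to compound 4 (0.46 log units; beyond the scatter) so a straight chain on this nitrogen can also reach the lower numbers that until now had been seen only with isopropyl. Straight propyl and branched isopropyl cannot be told apart, with a 1.2-fold higher number from compound 3 to compound 4 (0.07 log units; within the scatter) and so, among these compounds, the lower numbers do not depend on branching but appear with either of the two shorter groups, while pentyl and hexyl stay together at the higher numbers. The data offer no measurement that explains why the chain length matters here.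

A butyl chain would show whether the numbers climb gradually from propyl to pentyl or jump at a single length, and ethyl or methyl on the same nitrogen would show whether they keep falling as the chain gets shorter still. On these data alone, it also remains open how the result would change with a propyl chain carrying an amine or a carboxylic acid.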